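A few compounds are considered here, and "the series" means these few. Any claim that something is new, unique, unknown or untested is made for them only; others in the source may bear on it.

Within the data shown here, in an ADME assay on L6 cells (Rattus norvegicus) for cytotoxicity, read by resazurin assay, with a stated time of 72 h (on this read-out lower numbers stand for stronger inhibition and higher numbers for weaker inhibition), compound 2 (`OC(c1ccc(Cl)cc1)(c1cccnc1)c1ccc(Cl)cc1F`) gives 59400 nM as the only true number among the three measured compounds. Compound 1 (`N#Cc1cccc(C(O)(c2ccc(Cl)cc2)c2cccnc2)c1`) reports > 100000 nM as a limit and not a number. Compound 3 (`OC(c1ccc(C(F)(F)F)cc1)(c1cccnc1)c1ccc(Cl)cc1F`) likewise reports > 100000 nM as a limit. The evidence is therefore bounded by the limit of > 100000 nM in this assay, at which 2 of the 3 values shown sit, and offers little detail.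

Compound 4 (`CC(C)Oc1ccc(C(O)(c2ccc(Cl)cc2)c2cccnc2)c(F)c1`) has not yet been measured. It differs from compound 2 by isopropoxy in place of chloro on an aromatic carbon (isopropoxy in place of chloro on an aromatic carbon, meta to a fluoro group and para to a large group). One measured step comes close: trifluoromethyl in place of chloro on an aromatic carbon gave an at least 1.6-fold higher number from compound 2 to compound 3 (0.22 log units; that floor lies within the scatter) and leaves the true size unknown. That step replaced the other chloro of compound 2, not the one meta to a fluoro group, so it is only an indirect guide. No step beyond the scatter is therefore expected in this assay and no direction can be firmly argued. The expected change is a 1.3-fold lower number from compound 2 to compound 4 (0.12 log units; within the scatter) as an estimate, though a reading at the limit remains possible. Compound 4 is estimated at 45000 nM with 15000 nM to 100000 nM as the expected range.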

Compound 4, half-maximal inhibitory concentration: 58200 nM
Beside the measured number, compound 4's estimate is 1.3-fold (0.11 log units) below it; the range from low to high includes it.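

In this assay, isopropoxy in place of chloro on an aromatic carbon, meta to a fluoro group and para to a large group, gives a 1.0-fold lower number from compound 2 to compound 4 (0.01 log units; within the scatter). Among these compounds, at this position, then, a group of 4 heavy atoms that brings 1 hydrogen-bond acceptor can stand in place of a single chlorine without any change beyond the usual scatter of the read-out, something the earlier compounds, altered only at the other chloro, could not show. Among the compounds shown here, this is also the only step in the set with a true number at both ends, so its size can be read, whereas the earlier step from compound 2 to compound 3 gives only a floor because it ends at an assay limit: the limit of > 100000 nM in this assay, at which 2 of the 4 values shown sit.

What the compounds shown leave open is whether an amine, a carboxylic acid or a longer alkoxy chain at this same position would also leave the number within the scatter of compound 2, or would move it clearly in either direction. Also open, going by these compounds, is whether isopropoxy in place of the other chloro would give a true number or another limit.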